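The source may hold more compounds than are shown below. What is called first, only, known or untested is meant among the compounds shown, and "the series" means these compounds.

- Compound 1 `Cc1ccc(NS(=O)(=O)c2cccc(CCCCCCNC(=O)/C=C/c3cccnc3)c2)cc1`: 1.97 nM
- Compound 2 `Cc1ccccc1NS(=O)(=O)c1cccc(CCCCCCNC(=O)/C=C/c2cccnc2)c1`: 0.226 nM

In a functional assay on MCF7 cells (Homo sapiens) for inhibition, read by CCK-8 assay, with a stated time of 72 h (a lower number here means a stronger inhibitor, a higher number a weaker inhibitor), compound 2 gives 0.226 nM, the lower of the two numbers and beyond the scatter of the other. Compound 3 `Cc1cccc(NS(=O)(=O)c2cccc(CCCCCCNC(=O)/C=C/c3cccnc3)c2)c1` keeps the same atoms joined differently: 3-methylphenyl in place of 2-methylphenyl on a sulfonamide nitrogen, with 3-methylphenyl in place of 2-methylphenyl on a sulfonamide nitrogen. Among the measured compounds shown here, only one measured step bears on this change, an 8.7-fold lower number from compound 1 to compound 2 (0.94 log units; beyond the scatter), in which 2-methylphenyl took the place of 4-methylphenyl on the same nitrogen. For the measured compounds named here, that step lies beyond the scatter and is the only guide, since no 3-methylphenyl compound has a value yet. A higher number in this assay is therefore expected, though the rise should be smaller than that step. The expected step is a 3.1-fold higher number from compound 2 to compound 3 (0.49 log units; beyond the scatter). Compound 3 is estimated at 0.7 nM, with an expected range from 0.2 nM to 2.5 nM.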

Compound 3, half-maximal inhibitory concentration: 4 nM
Estimate against measurement, compound 3: 5.7-fold (0.76 log units) below; measured number above the stated range.
By their numbers in this assay, from the lowest: compound 2; then compound 1; then compound 3.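

Among the compounds shown here, with all three methylphenyl isomers in hand, this assay shows that the 2-methylphenyl group on the sulfonamide nitrogen stands apart: changing it to 3-methylphenyl gives an 18-fold higher number from compound 2 to compound 3 (1.25 log units; beyond the scatter), the largest step so far. The 3-methylphenyl group does not fall between the other two, as the change from 4-methylphenyl gives a 2.0-fold higher number from compound 1 to compound 3 (0.31 log units; beyond the scatter), so compound 2 is the most potent of the three and compound 3 the least. Nothing shown accounts for these differences.

The compounds shown leave open whether the low number of compound 2 depends on the methyl itself or would also hold for 2-ethylphenyl, 2-chlorophenyl or 2-methoxyphenyl on the same nitrogen. As far as these compounds go, how an unsubstituted phenyl group there would compare with all three isomers also remains open.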